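From 3-chlorophenyl to phenyl in a growth assay

This account rests on a few compounds, and the source may have more. Where it says the series, first, only, none or still open, it means among the compounds named here.

In a functional assay on BT-474 cells (Homo sapiens) for inhibition, read by fluorescence, with a stated time of 72 h (a lower number here means a stronger inhibitor of growth, a higher number a weaker inhibitor of growth), compound 2 `CCCCn1cnc2c(Nc3cccc(Cl)c3)nc(N[C@H]3CC[C@H](N)CC3)nc21` gives 5100 nM and compound 1 `CCCCn1cnc2c(Nc3ccc(Cl)cc3)nc(N[C@H]3CC[C@H](N)CC3)nc21` gives 7300 nM, so the two stand level within the scatter. Compound 3 `CCCCn1cnc2c(Nc3ccccc3)nc(N[C@H]3CC[C@H](N)CC3)nc21` differs from compound 2 by hydrogen in place of chloro on an aromatic carbon. Among the compounds with values here, only one measured step bears on this, and only indirectly: a 1.4-fold lower number from compound 1 to compound 2 (0.16 log units; within the scatter), with chloro present on both sides. Within the data shown here, no measured step removes chloro, so the data suggest no direction. The expected result is a 1.2-fold higher number from compound 2 to compound 3 (0.07 log units; within the scatter), a change no larger than the scatter. Compound 3 is estimated at 6000 nM, with an expected range of 2500 nM to 15000 nM.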

Compound 3, concentration for 50% growth inhibition: 4900 nM
Beside the measured number, compound 3's estimate is 1.2-fold (0.09 log units) above it; low and high end bracket the measured number.
By their numbers in this assay, from the lowest: compounds 3, 2 and 1 (each within the scatter of the next).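

Replacing the chloro with hydrogen gives (a 1.0-fold lower number from compound 2 to compound 3 (0.02 log units; within the scatter)), and the comparison with the 4-chlorophenyl compound gives (a 1.5-fold lower number from compound 1 to compound 3 (0.17 log units; within the scatter)). The earlier pair only moved the chloro, whereas these steps remove it, and neither takes the number beyond the scatter, so among these three compounds the chloro makes no readable difference. Nothing measured here offers an explanation for this result. From the compounds shown here alone, whether a methoxy group, an amine or a carboxylic acid on this aromatic ring would shift the number beyond the scatter remains open.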